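A group exchange on the chain of compound 1

The source may hold more compounds than are shown below. What is called first, only, known or untested is meant among the compounds shown, and "the series" means these compounds.

In a functional assay on Coronary artery (Bos taurus) (a higher number here means that more compound is needed for the effect, a lower number that less compound is needed), compound 1 (`CCCCCNC(=O)NCCCC/C=C\CCCCCS(=O)(=O)c1ncn[nH]1`) gives a half-maximal effective concentration of 3100 nM on the coronary artery preparation. Compound 2 (`CCCCNC(=O)C(=O)NCCCC/C=C\CCCCCCc1nnn[nH]1`) gives 1700 nM in this assay and so the two values lie within the usual scatter of each other. Among the measured compounds shown here, compound 1 therefore stands level with the only other number available. Compound 3 (`CCCCCNC(=O)NCCCC/C=C\CCCCCCc1nsc(=O)[nH]1`) differs from compound 1 in one place, on a saturated chain carbon, five bonds along the chain from a double-bonded chain carbon (a group of 7 heavy atoms (3 carbon, 2 nitrogen, 1 oxygen, 1 sulfur; one five-membered aromatic ring with 3 hetero atoms) in place of a group of 8 heavy atoms (2 carbon, 3 nitrogen, 2 oxygen, 1 sulfur; one five-membered aromatic ring with 3 hetero atoms), on a saturated chain carbon, five bonds along the chain from a double-bonded chain carbon). For the measured compounds named here, no measured pair shows this exchange on its own, so the data give no direct size for it. Going by the values given here, the only guide is that compound 1 and compound 2, with compound 2 at 1700 nM in spite of its different structure, sit close together. No change beyond the scatter is therefore expected, and the estimated 1.3-fold lower number from compound 1 to compound 3 (0.11 log units; within the scatter) remains small. In this assay compound 3 is estimated at 2400 nM with a range from 800 nM to 7000 nM as the expected span.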

Compound 3, half-maximal effective concentration: 2400 nM
For compound 3 middle estimate and measured number coincide at the digits printed, and the stated range covers the measured number.
By their numbers in this assay, from the lowest: compounds 2, 3 and 1 (each within the scatter of the next).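

In this assay the exchange gives a 1.3-fold lower number from compound 1 to compound 3 (0.11 log units; within the scatter), the first direct size for any exchange on a saturated chain carbon, five bonds along the chain from a double-bonded chain carbon. The group of 7 heavy atoms thus stands in for the group of 8 heavy atoms without a change beyond the scatter, although it carries 1 double bond outside aromatic rings instead of 2 and 3 hydrogen-bond acceptors instead of 4. Nothing at hand speaks to the reason for this result.

The compounds shown leave open whether this place would accept a group without one five-membered aromatic ring with 3 hetero atoms, such as a carboxylic acid or an amine, equally well. On these data alone, it also remains open whether the result would hold on a longer chain.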